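Stability of the amine side groups: compound 3 to compound 4

The compounds below may be only part of what the source reports. "The series", "measured", "known", "first", "only" and "open" are said of these compounds alone.

- compound 1 `N#Cc1cnc(NCc2cnccc2C(F)(F)F)cc1N[C@H]1C[C@@H](O)C1`: 90%
- compound 2 `N#Cc1cnc(NCc2cnccc2C(F)(F)F)cc1NC[C@H]1CC[C@H](O)CC1`: 32%
- compound 3 `N#Cc1cnc(NCc2cnccc2C(F)(F)F)cc1NCCC1CCOCC1`: 23%

All values come from an ADME assay on S9 fraction from liver (Homo sapiens) for metabolic stability, with a stated time of 1 h; on this read-out higher numbers stand for a more stable compound and lower numbers for a less stable compound. Compound 3, at 23%, stands level with the other compound that carries a chain to its ring, with a number 9 percentage points lower from compound 2 to compound 3 (within the scatter). The gap to the cyclobutyl compound is large, with a number 67 percentage points lower from compound 1 to compound 3 (beyond the scatter). The next compound is compound 4 `N#Cc1cnc(NCc2cnccc2C(F)(F)F)cc1N[C@H]1CC[C@@H](C(N)=O)CC1`, and the change is 4-carbamoylcyclohexyl in place of 2-(oxan-4-yl)ethyl on a nitrogen on an aromatic ring. The entering group resembles the 3-hydroxycyclobutyl of compound 1 in being a ring bound to the nitrogen on an aromatic ring. The relevant steps are therefore a number 67 percentage points lower from compound 1 to compound 3 (beyond the scatter) and a number 58 percentage points lower from compound 1 to compound 2 (beyond the scatter), both large. Among the compounds with values here, only compound 1 supports this comparison, however, and no measured compound carries a carbamoyl or has a cyclohexyl bound to that nitrogen. Only part of that gap is expected to be recovered, so a clear rise is expected, a number 37 percentage points higher from compound 3 to compound 4 (beyond the scatter). For compound 4 the estimated value is 60%, with an expected range of 35% to 85%.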

Compound 4, percent of the compound remaining: 90%
Compound 4: middle estimate off by 30 percentage points, on the low side, outside the stated range (above it).
By their numbers in this assay, from the lowest: compounds 3 and 2 (each within the scatter of the next); then compounds 1 and 4 (each within the scatter of the next).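

In this assay, the 4-carbamoylcyclohexyl on this nitrogen reads with compound 1 and not with the compounds that carry a chain: a number 67 percentage points higher from compound 3 to compound 4 (beyond the scatter), a number 58 percentage points higher from compound 2 to compound 4 (beyond the scatter), and no change at the digits printed from compound 1 to compound 4 (within the scatter). Within the data shown here, the 3-hydroxycyclobutyl is therefore not the only group at this place that gives a high number, and a six-membered ring of carbon only also does. Among these four compounds, the two with a ring bound directly to the nitrogen on an aromatic ring give high numbers and the two with a chain there give low numbers, with no compound going against this, but nothing here gives a reason for the split.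

Going by these compounds, how much of the rise belongs to the direct ring bond and how much to the carbamoyl stays open. A (4-carbamoylcyclohexyl)methyl group on the same nitrogen would separate the two.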